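A Longer Amide Chain on the Amine Nitrogen

This account rests on a few compounds, and the source may have more. Where it says the series, first, only, none or still open, it means among the compounds named here.

Compound 2 `COC(=O)CC(=O)NC1=CS(=O)(=O)O[C@@]12[C@@H](CO[Si](C)(C)C(C)(C)C)O[C@@H](n1cc(C)c(=O)n(C)c1=O)[C@@H]2O[Si](C)(C)C(C)(C)C` and compound 1 `Cc1cn([C@@H]2O[C@H](CO[Si](C)(C)C(C)(C)C)[C@@]3(OS(=O)(=O)C=C3NCC(N)=O)[C@H]2O[Si](C)(C)C(C)(C)C)c(=O)n(C)c1=O` share one core and differ only at an amine nitrogen. In a functional assay on MT4 cells (Homo sapiens) (on this read-out higher numbers stand for lower toxicity in this test and lower numbers for higher toxicity in this test), compound 2 gives 11900 nM and compound 1 gives 14900 nM, a difference of a 1.3-fold lower number from compound 1 to compound 2 (0.10 log units; within the scatter), so both stand together. Compound 3 `Cc1cn([C@@H]2O[C@H](CO[Si](C)(C)C(C)(C)C)[C@@]3(OS(=O)(=O)C=C3NCCC(N)=O)[C@H]2O[Si](C)(C)C(C)(C)C)c(=O)n(C)c1=O` follows from compound 2 by 2-carbamoylethyl in place of ((methoxycarbonyl)methyl)carbonyl on an amine nitrogen. For the measured compounds named here, the one measured step at this position, a 1.3-fold lower number from compound 1 to compound 2 (0.10 log units; within the scatter), stayed within the scatter, and compound 3 is therefore expected to shift by a 1.1-fold higher number from compound 2 to compound 3 (0.05 log units; within the scatter) in this assay. The estimate for compound 3 is 13500 nM, ranging from 6000 nM to 30000 nM.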

Compound 3, half-maximal cytotoxic concentration: 20000 nM
For compound 3 the middle estimate is 1.5-fold (0.17 log units) below the measured one; the range from low to high includes it.
By their numbers in this assay, from the lowest: compounds 2, 1 and 3 (each within the scatter of the next).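

In this assay, 2-carbamoylethyl on the amine nitrogen stays within the scatter of both earlier groups (a 1.7-fold higher number from compound 2 to compound 3 (0.23 log units; within the scatter); a 1.3-fold higher number from compound 1 to compound 3 (0.13 log units; within the scatter)). Thus the three groups on this nitrogen, including carbamoylmethyl and its one-carbon-longer 2-carbamoylethyl counterpart, cannot be told apart on this read-out. No evidence is available that bears on these numbers. What the compounds shown leave open is whether a carboxylic acid, an amine or a still longer chain on this nitrogen would stay within the same scatter.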